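The source may report more compounds than this note shows. Statements on the series, on what has been measured and on what is new or still open speak of the compounds shown alone.

Measured compounds in hand:

compound 1, `Cc1nc(-c2ccc(C(F)(F)F)cc2)sc1CNc1ccc(CCC(=O)O)cc1`: 108%
compound 2, `Cc1nc(-c2ccc(C(F)(F)F)cc2)sc1CNc1ccc(CCC(N)=O)cc1`: 88%

Both numbers come from a functional assay on CHO cells for agonist activity at Free fatty acid receptor 1 (Homo sapiens), read by a luciferase reporter; on this read-out higher numbers stand for larger maximal responses and lower numbers for smaller maximal responses. Compound 2 stands lowest of the two, its nearest neighbour being compound 1, which gives 108% in this assay. For the measured compounds named here, the only step yet measured, a number 20 percentage points lower from compound 1 to compound 2 (beyond the scatter), is the change of amino in place of hydroxy on a carbonyl carbon, and it runs downward.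

Compound 3, `Cc1nc(-c2ccc(C(F)(F)F)cc2)sc1CNc1ccc([C@H]2C[C@@H]2C(=O)N(C)C)cc1`, is not yet measured. It differs from compound 2 at one place: 2-(dimethylcarbamoyl)cyclopropyl in place of 2-carbamoylethyl on an aromatic carbon. The group that enters keeps the carbonyl and its acceptor, loses the donor of the carbamoyl and brings the three-membered ring with two defined stereocentres.

Going by the values given here, only the step from compound 1 to compound 2 bears on this change, and then only loosely, since it also alters what sits on the carbonyl carbon; that step was modest. For compound 3 a step of a number 8 percentage points lower from compound 2 to compound 3 (within the scatter) is therefore expected, a small loss that may well fall within the scatter. The value of compound 3 in this assay is estimated at 80%, with a range from 55% to 100%.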

Compound 3, largest response reached (reported as percent of maximum), in percent of the reference or control that the assay uses: 49%
Beside the measured number, compound 3's estimate is 31 percentage points above it, and the stated range ends above it.
By their numbers in this assay, from the lowest: compound 3; then compound 2; then compound 1.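

In this assay the position para to a large group proves far less forgiving than the change on the carbonyl carbon suggested: 2-(dimethylcarbamoyl)cyclopropyl in place of 2-carbamoylethyl gives a number 39 percentage points lower from compound 2 to compound 3 (beyond the scatter), while a number 20 percentage points lower from compound 1 to compound 2 (beyond the scatter) had been only a modest loss. Set against the 2-carboxyethyl group, the same entering group gives a number 59 percentage points lower from compound 1 to compound 3 (beyond the scatter), so in this small set a carbonyl with its hydrogen-bond acceptor at this position is not enough to hold the maximal response. No measurement at hand accounts for the loss.

The change brings in the three-membered ring, its two defined stereocentres and the two methyl groups on the amide nitrogen together, with the amide hydrogens gone, and the compounds shown do not separate these parts. From the compounds shown here alone, it stays open whether the open 2-(dimethylcarbamoyl)ethyl chain, or a cyclopropyl ring carrying a carboxylic acid or an unsubstituted carbamoyl, or the opposite stereoisomer of the ring, would keep more of the response.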